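The source may report more compounds than this note shows. Statements on the series, on what has been measured and on what is new or still open speak of the compounds shown alone.

In a functional assay on FaDu cells (Homo sapiens) for cytotoxicity, read by MTT assay, with a stated time of 72 h (on this read-out higher numbers stand for lower toxicity in this test and lower numbers for higher toxicity in this test), compound 1, with the structure `COc1ccc(NC(=O)C(=O)c2cn(C(C)(C)COCC(=O)O)c3ccccc23)cn1`, gives only a limit of the assay, > 10000 nM, and no exact number. Compound 2, with the structure `CC(C)n1cc(C(=O)C(=O)Nc2ccc(C(F)(F)F)nc2)c2ccccc21`, is measured in this assay with the same result: a limit, > 10000 nM. So compound 1 stands nowhere in particular among the numbers shown: it sits at the limit of > 10000 nM in this assay, at which 2 of the 2 values shown sit, with nothing placed higher or lower than it.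

Compound 3, with the structure `COc1ccc(NC(=O)C(=O)c2cn(CCOC(C)C)c3ccccc23)cn1`, differs from compound 1 in one place: a group of 6 heavy atoms (5 carbon, 1 oxygen; no ring) in place of a group of 9 heavy atoms (6 carbon, 3 oxygen; no ring), on an aromatic nitrogen. Within the data shown here, no step between two measured compounds is known here, so the size of this change cannot be read from a measured pair. Given that compound 1 shows only a limit in this assay, > 10000 nM, the expected step that the limit leaves unreadable from compound 1 to compound 3 is none beyond the scatter. Compound 3 is therefore estimated at 15000 nM, within the range from 4000 nM to 60000 nM, most likely reported again as a limit.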

Compound 3, concentration lethal to 50% of the cells: 211 nM
Compound 3: the middle estimate sits 71-fold (1.85 log units) above what was measured; measured number outside the range, below it.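

This position on the aromatic nitrogen proves able to decide the outcome: with the rest of the molecule unchanged, replacing the larger chain of compound 1 with 2-isopropoxyethyl gives an at least 47-fold lower number from compound 1 to compound 3 (1.67 log units; beyond the scatter). In this assay, a lower number means higher toxicity, so this one change turns a compound without a measurable lethal concentration into one with an exact value. The other compounds still give no exact number, only a limit: the limit of > 10000 nM in this assay, at which 2 of the 3 values shown sit.

Because compound 1 gives only a limit, the full size of the step cannot be read, and a single pair cannot show which feature of the exchanged chains matters. On these data alone, whether a simple amine or a longer ether chain at this position would keep the toxicity of compound 3 remains open.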